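The source may report more compounds than this note shows. Statements on the series, on what has been measured and on what is new or still open speak of the compounds shown alone.

Compound 1 `Nc1cc(N)c2nc(-c3ccccc3)c(Oc3ccc(Cl)c(Cl)c3)nc2c1`: 58900 nM
Compound 2 `Nc1cc(N)c2nc(-c3ccccc3)c(NCc3ccc(F)cc3)nc2c1`: 7590 nM
Compound 3 `Nc1cc(N)c2nc(-c3ccccc3)c(Sc3ccc(Cl)c(Cl)c3)nc2c1`: 58900 nM

Of the compounds shown here, three sharing one core have been tested in a functional assay on OVCAR-5 cells (Homo sapiens) for inhibition, read by sulforhodamine B assay, with a stated time of 48 h; on this read-out lower numbers stand for stronger inhibition of growth and higher numbers for weaker inhibition of growth. Compound 3 stands level with compound 1; these two give the highest numbers of the three, and the gap between them lies within the scatter, as the step of no change at the digits printed from compound 1 to compound 3 (within the scatter) shows. Compound 2 sits apart: the step of a 7.8-fold higher number from compound 2 to compound 3 (0.89 log units; beyond the scatter) is beyond the scatter, so compound 2 is the only one of the three clearly different from the other two.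

Compound 4 `Nc1cc(N)c2nc(-c3ccccc3)c(Sc3ccc(F)cc3)nc2c1` is the next compound. Compared with compound 3 the change is 4-fluorophenyl in place of 3,4-dichlorophenyl on a sulfur. For the measured compounds named here, no measured step isolates this swap of the ring on the sulfur. The closest guide is a 7.8-fold lower number from compound 1 to compound 2 (0.89 log units; beyond the scatter), where a 4-fluoro-bearing group replaced the 3,4-dichlorophenoxy group, but that step changed the linker as well as the ring. The step of no change at the digits printed from compound 1 to compound 3 (within the scatter) says only that oxygen against sulfur in the linker made no difference. The expectation for compound 4 is therefore a modest lower number than compound 3, with wide uncertainty, and the estimated step is a 2.0-fold lower number from compound 3 to compound 4 (0.29 log units; within the scatter). Compound 4 is estimated to give 30000 nM in this assay, within a range from 10000 nM to 80000 nM.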

Compound 4, concentration for total growth inhibition: 45700 nM
Compound 4: middle estimate off by 1.5-fold (0.18 log units), on the low side; measured number inside the range.
By their numbers in this assay, from the lowest: compound 2; then compounds 4, 1 and 3 (each within the scatter of the next).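

Placing 4-fluorophenyl where 3,4-dichlorophenyl stood on the sulfur gives a 1.3-fold lower number from compound 3 to compound 4 (0.11 log units; within the scatter) in this assay and so, seen on its own for the first time, this ring swap leaves the number unchanged within the scatter. Compound 4 also matches the oxygen-linked compound 1 (a 1.3-fold lower number from compound 1 to compound 4 (0.11 log units; within the scatter)), yet it remains clearly apart from compound 2 (a 6.0-fold higher number from compound 2 to compound 4 (0.78 log units; beyond the scatter)) even though both carry a fluorine-bearing ring. The fluorine-bearing ring alone therefore does not bring the sulfur-linked compound to the level of compound 2, which points to the (4-fluorobenzyl)amino group as a whole as what sets compound 2 apart, although nothing here gives a reason for this.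

Going by these compounds, compound 2 and compound 4 differ in both the linker atom and the benzyl part, so it remains open which of the two matters; a (4-fluorophenyl)amino group and a (4-fluorobenzyl)sulfanyl group would each separate them. On these data alone, it is also open whether other amines at this position, such as a plain benzylamino group or a longer phenethylamino chain, would behave like compound 2.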